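The source may report more compounds than this note shows. Statements on the series, on what has been measured and on what is new or still open speak of the compounds shown alone.

Compound 1: `Nc1nn(C(=O)Nc2ccc(Cc3ccccc3)cc2)c2ccccc12` — "not determined" (no result reported).
Compound 2: `Nc1nn(C(=O)Nc2ccc(Cc3ccccc3)cc2)c2ccc(Cl)cc12` — 81.3 nM.

In a functional assay on MDA-MB-435 cells (Homo sapiens) for antiproliferative activity, read by sulforhodamine B assay, with a stated time of 48 h (on this read-out lower numbers stand for stronger inhibition of growth and higher numbers for weaker inhibition of growth), compound 2 gives 81.3 nM, the only number shown, since compound 1 carries no result there. Compound 3 `Nc1ccc2c(c1)c(N)nn2C(=O)Nc1ccc(Cc2ccccc2)cc1` differs from compound 2 by amino in place of chloro on an aromatic carbon. Among the measured compounds shown here, no step between two measured compounds exists to gauge such a change, so only a modest shift, at the edge of the usual scatter, is expected, and the estimated step is a 1.8-fold higher number from compound 2 to compound 3 (0.27 log units; within the scatter). In this assay compound 3 is expected to give 150 nM, within a range from 40 nM to 600 nM.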

Compound 3, concentration for 50% growth inhibition: 7360 nM
Beside the measured number, compound 3's estimate is 49-fold (1.69 log units) below it; the whole stated range lies below it.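

In this assay amino in place of chloro on this aromatic carbon brings a 91-fold higher number from compound 2 to compound 3 (1.96 log units; beyond the scatter) and so moves growth inhibition far more than repeat measurements would. This shows that the group at this one position of the shared core matters strongly, which a single value could not reveal. On these data alone, compound 1 has no result, so it remains open how hydrogen at this position compares with chloro or amino, and how a group such as methoxy or fluoro would fare. No measurement shown explains this large step.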